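The source may hold more compounds than are shown below. What is called first, only, known or untested is meant among the compounds shown, and "the series" means these compounds.

Of the compounds shown here, two have so far been measured in a functional assay on the whole organism with Rattus norvegicus as the target; a higher number here means that more compound is needed for the effect, a lower number that less compound is needed. Compound 1, `CC1CCC(=NNc2ccccc2)c2ncc(C(=O)NO)c(=O)n21`, gives in this assay only a limit, > 100 umol/kg, and no number. Going by the values given here, compound 2, `Cc1cccc(C)c1NN=C1CCC(C)n2c1ncc(C(=O)O)c2=O`, gives 320 umol/kg in this assay, which is the only number among the values shown. The other value in this assay is the limit of > 100 umol/kg in this assay, at which 1 of the 2 values shown sits, and it belongs to compound 1. The step under consideration goes from compound 2 to compound 3, `Cc1cc(NN=C2CCC(C)n3c2ncc(C(=O)O)c3=O)ccc1Br`, which differs from compound 2 by 4-bromo-3-methylphenyl in place of 2,6-dimethylphenyl on an amine nitrogen. Among the compounds with values here, no pair of measured compounds differs in a single place, so no measured step in this assay guides the expectation. The step from compound 2 to compound 3 in this assay, a 1.3-fold lower number from compound 2 to compound 3 (0.11 log units; within the scatter), is expected to stay within the usual scatter, in no clear direction. Compound 3 is therefore estimated at 250 umol/kg in this assay, with a range from 70 umol/kg to 900 umol/kg.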

Compound 3, dose for 50% inhibition: > 100 umol/kg
Compound 3 gave a limit, no number; the forecaster's own chance of this, stated with the estimate: 30%; the middle value does not contradict the limit.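

In this assay compound 3 gives > 100 umol/kg, which is a limit and not a number, and no new step can be read between compound 2 and compound 3. The compounds shown leave open how large any change from 2,6-dimethylphenyl to 4-bromo-3-methylphenyl is, and in which direction it runs.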